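Amide chain homologation on the shared core

A few compounds are considered here, and "the series" means these few. Any claim that something is new, unique, unknown or untested is made for them only; others in the source may bear on it.

Measured compounds:
compound 1, `CCNC(=O)c1cc(Sc2cnc(Nc3ccccn3)s2)ccc1C` — in a functional assay on SH-SY5Y cells (Homo sapiens) for antiproliferative activity, with a stated time of 3 days (on this read-out lower numbers stand for stronger inhibition and higher numbers for weaker inhibition), compound 1 gives > 10000 nM, which is a limit of the assay and not a number.
compound 2, `Cc1ccc(Sc2cnc(Nc3cccc(Br)n3)s2)cc1C(=O)N(C)CC#N` — in this assay compound 2 gives 750 nM.

Among the measured compounds shown here, compound 2 holds the only number in this assay; the remaining value is a limit. Compound 1 sits at that limit, (the limit of > 10000 nM in this assay, at which 1 of the 2 values shown sits). For the measured compounds named here, no pair of these two differs in a single place, so no measured step links them; each is taken on its own.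

Compound 3, `Cc1ccc(Sc2cnc(Nc3cccc(Br)n3)s2)cc1C(=O)N(C)CCC#N`, is not yet measured. It differs from compound 2 in one place: cyanomethyl in place of cyano on a saturated chain carbon bound to an amide-type nitrogen. The amide nitrogen and its methyl are kept; only the chain that carries the nitrile grows by one carbon.

Going by the values given here, no measured step of this kind exists, so the expectation rests on the change itself. Lengthening the chain by one saturated carbon is expected to move this read-out little, and the expected step of a 1.2-fold higher number from compound 2 to compound 3 (0.08 log units; within the scatter) is estimated to stay within the usual scatter. Compound 3 is thus expected to give about 900 nM in this assay, with a range from 300 nM to 3000 nM.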

Compound 3, half-maximal inhibitory concentration: 1170 nM
Compound 3: middle estimate off by 1.3-fold (0.11 log units), on the low side, within the range that was stated.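

In this assay, among the compounds shown here, the only measured step at this position is a 1.6-fold higher number from compound 2 to compound 3 (0.19 log units; within the scatter), the first direct reading of this change on the saturated chain carbon bound to the amide-type nitrogen. On this read-out, the cyanomethyl and 2-cyanoethyl chains on the amide nitrogen cannot be told apart, so this position accepts the one-carbon extension of the chain without a change that stands out from the scatter. Nothing shown bears on why this step is as it is.

Still open, from the compounds shown here alone, is how this assay responds to a chain longer than 2-cyanoethyl, or to an amine or a carboxylic acid in place of the nitrile. Compound 1 gives > 10000 nM, which is a limit of the assay and not a number, and it differs from compound 2 and compound 3 in more than one place, so which of those differences accounts for its separate standing remains unresolved.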